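Chloro for methylsulfonyl on the phenyl of compound 3

The compounds below may be only part of what the source reports. "The series", "measured", "known", "first", "only" and "open" are said of these compounds alone.

Compound 3 `Cc1ccc(C2=NN(c3nc(-c4ccc(S(C)(=O)=O)cc4)cs3)C(c3ccc(F)cc3)C2)s1` in a functional assay on A549 cells (Homo sapiens) for antiproliferative activity, read by XTT assay, with a stated time of 24 h (on this read-out higher numbers stand for weaker inhibition and lower numbers for stronger inhibition), gives only a limit, > 500 ug/mL. Compound 2 `Cc1ccc(-c2csc(N3N=C(c4ccc(C)s4)CC3c3ccc(F)cc3)n2)cc1` also gives only a limit in this assay, > 500 ug/mL. Among the measured compounds shown here, compound 1 `Fc1ccc(C2CC(c3ccc(Cl)s3)=NN2c2nc(-c3ccc(Cl)cc3)cs2)cc1` is the one compound with a number in this assay, 125 ug/mL. The single measured step, a step that the two limits leave unreadable from compound 2 to compound 3, cannot be read because the limit of > 500 ug/mL in this assay, at which 2 of the 3 values shown sit, leaves both ends open, so nothing in the shown steps tells how a change on the phenyl moves this read-out.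

Compound 4 `Cc1ccc(C2=NN(c3nc(-c4ccc(Cl)cc4)cs3)C(c3ccc(F)cc3)C2)s1` differs from compound 3 by chloro in place of methylsulfonyl on an aromatic carbon. For the measured compounds named here, no measured step bears on this change. Compound 1 and compound 4 share the 4-chlorophenyl and differ only on the other aryl ring, and compound 1 is the only compound shown with a number rather than a limit. Compound 4 is therefore expected in the region between the number of compound 1 and the limit, with the expected step of an at least 2.0-fold lower number from compound 3 to compound 4 (0.30 log units; that floor lies within the scatter) unreadable in size from compound 3. Compound 4 is estimated at 250 ug/mL, with a range from 80 ug/mL to 600 ug/mL, and a fair chance that only a limit is reported.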

Compound 4, half-maximal inhibitory concentration: > 500 ug/mL
Compound 4: a limit, no number (the forecaster's own chance of this, stated with the estimate: 40%); middle value at least 2.0-fold (0.30 log units) away from the limit.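

In this assay, among the compounds shown here, the first readable step is an at least 4.0-fold higher number from compound 1 to compound 4 (0.60 log units; beyond the scatter), for methyl in place of chloro on an aromatic carbon. Compound 4, which carries the 4-chlorophenyl, gives only a limit, > 500 ug/mL, so that group alone does not bring a number in this assay. The steps among compound 2, compound 3 and compound 4 cannot be read, because all three sit at the same limit: the limit of > 500 ug/mL in this assay, at which 3 of the 4 values shown sit.

From the compounds shown here alone, how far compound 2, compound 3 and compound 4 lie beyond that limit stays open, so the methylsulfonyl, chloro and methyl on the phenyl cannot be ranked against one another. Also open, going by these compounds, is whether an amine or a carboxylic acid on the phenyl, or a bromo or an ethyl in place of the methyl of compound 4, would give a number.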